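A few compounds are considered here, and "the series" means these few. Any claim that something is new, unique, unknown or untested is made for them only; others in the source may bear on it.

Measured so far in a functional assay on SK-MEL-147 cells (Homo sapiens) for cytotoxicity, read by MTT assay, with a stated time of 24 h; a lower number here means that less compound is needed, a higher number that more compound is needed for the effect:
compound 1 `CCOC(=O)c1cc([Se]Cc2ccccc2)c2cc(OC)ccc2n1` gives 40700 nM
compound 2 `CCOC(=O)c1cc([Se]c2ccccc2)c2cc(Cl)ccc2n1` gives 47100 nM
compound 3 `CCOC(=O)c1cc([Se]c2ccccc2)c2ccccc2n1` gives 86300 nM

Compound 2 sits within the scatter of both compound 1 and compound 3, so no order is read into either pair. Compound 4 `CCOC(=O)c1cc([Se]Cc2ccccc2)c2cc(Cl)ccc2n1` differs from compound 2 by benzyl in place of phenyl on a selenium and so carries benzyl in place of phenyl on a selenium. For the measured compounds named here, the only measured step, a 1.8-fold higher number from compound 2 to compound 3 (0.26 log units; within the scatter) for hydrogen in place of chloro, does not touch this place. Compound 1 also holds benzyl and gives 40700 nM but has no measured phenyl partner. The data therefore give no reason to expect a step beyond the scatter in this assay for this change. The expected step is a 1.2-fold lower number from compound 2 to compound 4 (0.07 log units; within the scatter) on this reading. For compound 4 the estimated value is 40000 nM with an expected range from 17000 nM to 90000 nM at this stage.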

Compound 4, half-maximal effective concentration: 84500 nM
Estimate against measurement, compound 4: 2.1-fold (0.32 log units) below; measured number inside the range.
By their numbers in this assay, from the lowest: compounds 1, 2, 4 and 3 (each within the scatter of the next, the first and the last beyond it).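

In this assay benzyl in place of phenyl on a selenium now has a measured step: a 1.8-fold higher number from compound 2 to compound 4 (0.25 log units; within the scatter). With benzyl held on the selenium, chloro in place of methoxy on an aromatic carbon gives a 2.1-fold higher number from compound 1 to compound 4 (0.32 log units; beyond the scatter), a modest change and the only step shown beyond the scatter. No evidence bearing on either step is available.

Still open, from the compounds shown here alone, is whether the chloro and methoxy exchange reads the same with phenyl on the selenium. Also open, going by these compounds, is how a longer chain such as phenethyl, or an amine, would read on the selenium.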